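The source may report more compounds than this note shows. Statements on the series, on what has been measured and on what is new or still open speak of the compounds shown alone.

For the measured compounds named here, compound 2 `C#CCN(C)Cc1ccc(NC(=O)CCCCCCCC(=O)NO)cc1` is the only compound of the pair measured so far that yields a number in a functional assay on DU-145 cells (Homo sapiens) for inhibition, read by MTT assay, with a stated time of 48 h; on this read-out lower numbers stand for stronger inhibition of growth and higher numbers for weaker inhibition of growth: compound 2 gives 3400 nM. Its shorter partner, compound 1 `C#CCN(C)Cc1ccc(NC(=O)CCCCC(=O)NO)cc1`, reaches only a limit in this assay, where compound 1 gives > 10000 nM. Going by the values given here, the single measured step, an at least 2.9-fold lower number from compound 1 to compound 2 (0.46 log units; beyond the scatter), is thus the only guide, and it rests on the limit (the limit of > 10000 nM in this assay, at which 1 of the 2 values shown sits), so its true size stays open. Compound 3 `C#CCN(C)Cc1ccc(NC(=O)CCCCCCCCC(=O)NO)cc1` differs from compound 2 by (hydroxycarbamoyl)methyl in place of hydroxycarbamoyl on a saturated chain carbon, seven bonds along the chain from a carbonyl carbon, the same difference as before, cut one bond further out. Given that the longer chain gave a lower number in an at least 2.9-fold lower number from compound 1 to compound 2 (0.46 log units; beyond the scatter), and that this change adds less, compound 3 is expected to shift within the scatter or slightly downward in this assay, as a 1.4-fold lower number from compound 2 to compound 3 (0.13 log units; within the scatter). Compound 3 is accordingly estimated at 2500 nM, between 900 nM and 7000 nM.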

Compound 3, concentration for 50% growth inhibition: 2740 nM
Compound 3: the middle estimate sits 1.1-fold (0.04 log units) below what was measured, and the stated range covers the measured number.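

In this assay, the step of a 1.2-fold lower number from compound 2 to compound 3 (0.09 log units; within the scatter) lies within the scatter, so (hydroxycarbamoyl)methyl in place of hydroxycarbamoyl, seven bonds along the chain from a carbonyl carbon, brings no change that can be told apart from repeat measurement. The clear drop seen on the earlier lengthening therefore does not continue by any readable amount at this position. Over the full span the change is an at least 3.6-fold lower number from compound 1 to compound 3 (0.56 log units; beyond the scatter), which lies beyond the scatter, but its true size stays open: the limit of > 10000 nM in this assay, at which 1 of the 3 values shown sits.

The compounds shown leave open whether a longer chain, such as 2-(hydroxycarbamoyl)ethyl at this place, would stay level or move the number in either direction. They also leave open how a carboxylic acid in place of the hydroxycarbamoyl end would read out on the same core.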